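Series notes: groups on the ring amine nitrogen

This account rests on a few compounds, and the source may have more. Where it says the series, first, only, none or still open, it means among the compounds named here.

Measured so far:
compound 1 `Nc1scc(CN2CCN(c3cccc(F)c3)CC2)c1C(=O)c1cccc(C(F)(F)F)c1` — -62%
compound 2 `Nc1scc(CN2CCN(c3c(F)cccc3F)CC2)c1C(=O)c1cccc(C(F)(F)F)c1` — 4%
compound 3 `Nc1scc(CN2CCN(C3CCCCCC3)CC2)c1C(=O)c1ccc(Cl)cc1` — -25%

In a functional assay on CHO cells with adenosine receptor A1 (Homo sapiens) as the target, read by cAMP accumulation and immunoassay, with a stated time of 6 min, tested at 10 uM (on this read-out higher numbers stand for a weaker effect at the one concentration tested and lower numbers for a stronger effect), compound 3 stands second highest of the three numbers, nearest compound 2 and furthest from compound 1, with both gaps beyond the scatter. Compound 4 `Nc1scc(CN2CCN(c3ccc(Cl)c(Cl)c3)CC2)c1C(=O)c1ccc(Cl)cc1` differs from compound 3 by 3,4-dichlorophenyl in place of cycloheptyl on an amine nitrogen in a ring. Among the compounds with values here, the only measured step at this position, a number 66 percentage points higher from compound 1 to compound 2 (beyond the scatter), swaps one aryl pattern for another and was large; no step exchanges a saturated ring for an aryl ring, so it bears only loosely here. The two aryl compounds 1 and 2 bracket compound 3 on either side, so no direction beyond the scatter is expected. Compound 4 is therefore estimated at -30%, range -65% to 10%, a step of a number 5 percentage points lower from compound 3 to compound 4 (within the scatter) expected to lie within the scatter.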

Compound 4, a percentage reported as activity, at one concentration (the size of the read-out at that concentration, not a potency): -62%
Compound 4: the middle estimate sits 32 percentage points above what was measured, and the stated range covers the measured number.
By their numbers in this assay, from the lowest: compounds 1 and 4 (each within the scatter of the next); then compound 3; then compound 2.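

Within the data shown here, the step of a number 37 percentage points lower from compound 3 to compound 4 (beyond the scatter) in this assay is the first exchange of a saturated carbon ring for an aromatic ring on this amine nitrogen in a ring. Together with the step of a number 66 percentage points higher from compound 1 to compound 2 (beyond the scatter) it shows that large steps at this position arise both between two aryl groups and between a non-aromatic and an aromatic ring. No measured evidence accounts for this step. Open, on these data alone, is whether the aromatic ring or the two chlorine atoms carry the step, which an unsubstituted phenyl on this nitrogen would separate. Also open, as far as these compounds go, is how an aryl group bearing a carboxylic acid or an amine would read here.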